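The compounds below may be only part of what the source reports. "The series", "measured", "known", "first", "only" and "open" are said of these compounds alone.

Compound 1, `O=C1C(NC2CCCC2)=CC(=O)c2c1nc1n2[C@H]2OC[C@@H](O)[C@H]2OC1`, in a functional assay on HeLa cells (Homo sapiens) for inhibition, read by sulforhodamine B assay (on this read-out lower numbers stand for stronger inhibition and higher numbers for weaker inhibition), gives > 16000 nM, which is a limit of the assay and not a number.
Compound 2, `O=C1C=C(Nc2ccc(Br)cc2)C(=O)c2c1nc1n2[C@H]2OC[C@@H](O)[C@H]2OC1`, in this assay gives 3830 nM.
Compound 3, `CCOc1ccccc1NC1=CC(=O)c2nc3n(c2C1=O)[C@H]1OC[C@@H](O)[C@H]1OC3`, in this assay gives 6040 nM.

These three compounds share one core and differ only in the group on the amine nitrogen. Compound 1, with cyclopentyl there, stands at the limit of > 16000 nM in this assay, at which 1 of the 3 values shown sits, so its true value is not known beyond that bound. Among the measured compounds shown here, compounds 2 and 3 carry 4-bromophenyl and 2-ethoxyphenyl on that nitrogen; the one measured step, a 1.6-fold higher number from compound 2 to compound 3 (0.20 log units; within the scatter), shows that exchanging one aryl group for another leaves the number where it was.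

Compound 4, `O=C1C(Nc2cccc(Cl)c2)=CC(=O)c2c1nc1n2[C@H]2OC[C@@H](O)[C@H]2OC1`, is not yet measured. It differs from compound 1 by 3-chlorophenyl in place of cyclopentyl on an amine nitrogen. For the measured compounds named here, no measured step covers cyclopentyl against an aryl group, so the expectation rests on what compounds 2 and 3 show: both arylamines give a number within the range of this assay, while compound 1 gives only a limit. Compound 4 is therefore expected to read near compounds 2 and 3, with an at least 3.3-fold lower number from compound 1 to compound 4 (0.52 log units; beyond the scatter) as the implied step from the bound of compound 1. The estimate for compound 4 is 4800 nM, with a range from 2000 nM to 12000 nM.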

Compound 4, half-maximal inhibitory concentration: 7970 nM
Compound 4: the middle estimate sits 1.7-fold (0.22 log units) below what was measured; the range from low to high includes it.
By their numbers in this assay, from the lowest: compounds 2, 3 and 4 (each within the scatter of the next, the first and the last beyond it). At a limit, above all of these: compound 1.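

In this assay, an aryl group and cyclopentyl can now be compared directly on the same amine nitrogen of the shared core, and 3-chlorophenyl in place of cyclopentyl gives an at least 2.0-fold lower number from compound 1 to compound 4 (0.30 log units; that floor lies within the scatter). Going by these compounds, this step can be read only as a floor, so it does not establish a change beyond the scatter, and its true size stays unknown because compound 1 stands at a limit of the assay and not at a number: the limit of > 16000 nM in this assay, at which 1 of the 4 values shown sits. The new value also shows that the choice of aryl group is not always without consequence: compound 2 gives 3830 nM and compound 4 gives 7970 nM, a gap beyond the scatter, although compound 3 lies within the scatter of each.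

Compound 2 and compound 4 differ in both the halogen and its place on the phenyl ring, so the compounds shown cannot separate these two changes, which a 4-chlorophenyl group on the same nitrogen could begin to do. They also leave open how an unsubstituted phenyl, a cyclohexyl or an open-chain butyl group would read at this position.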